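Swapping One Saturated Ring for Another in a Weak Series

The source may report more compounds than this note shows. Statements on the series, on what has been measured and on what is new or still open speak of the compounds shown alone.

In an assay on HEK293 cells for inhibition of transient receptor potential cation channel subfamily M member 8 (Homo sapiens), read by FLIPR, with stated times of 5 min and 3 min (on this read-out lower numbers stand for stronger inhibition and higher numbers for weaker inhibition), compound 1 `O=C(c1sc(-c2cccc(F)c2)nc1O)N1CCCOC1` gives > 100000 nM, which is a limit of the assay rather than a number. Compound 1 thus stands at the limit of > 100000 nM in this assay, at which 2 of the 3 values shown sit. Compound 2 `O=C(O)c1sc(-c2ccccc2)nc1O` gives > 100000 nM in this assay, again a limit. Within the data shown here, compound 3 `CCOC(=O)c1sc(-c2ccccc2)nc1NC(=O)C(F)(F)F` gives 7700 nM in this assay, the only number among the three. No two of these compounds differ in a single place, so no measured step can be read from them. Compound 4 `O=C(c1sc(-c2cccc(F)c2)nc1O)N1CCOCC1` differs from compound 1 by a group of 6 heavy atoms (4 carbon, 1 nitrogen, 1 oxygen; one six-membered non-aromatic ring with 2 hetero atoms) in place of a group of 6 heavy atoms (4 carbon, 1 nitrogen, 1 oxygen; one six-membered non-aromatic ring with 2 hetero atoms), on a carbonyl carbon. Among the measured compounds shown here, with no measured step to lean on, the expected step from compound 1 to compound 4 is a number no higher from compound 1 to compound 4 (the limit leaves the size open), nothing beyond the scatter. Compound 4 is therefore estimated at 100000 nM, with a range from 30000 nM to 300000 nM, and most likely reported again only as a limit.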

Compound 4, half-maximal inhibitory concentration: 12200 nM
Compound 4: middle estimate off by 8.2-fold (0.91 log units), on the high side; measured number below the stated range.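

At this carbonyl carbon, in this assay, the placement of the ring oxygen matters: with the same atoms joined differently, morpholin-4-yl brings an at least 8.1-fold lower number from compound 1 to compound 4 (0.91 log units; beyond the scatter). Among these compounds, this is the first step that can be read, and it shows that a change confined to this saturated ring can yield a measurable number on the shared core. Its full size stays open, since the value for compound 1 is only a limit: the limit of > 100000 nM in this assay, at which 2 of the 4 values shown sit.

From the compounds shown here alone, what a piperidin-1-yl or a dimethylamino group would give on this carbonyl carbon remains open. So does whether the step would hold on another core.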